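A few compounds are considered here, and "the series" means these few. Any claim that something is new, unique, unknown or untested is made for them only; others in the source may bear on it.

Three compounds sharing one core have numbers in a functional assay on HeLa cells (Homo sapiens) for inhibition, read by MTT assay, with a stated time of 72 h; a higher number here means a weaker inhibitor, a lower number a stronger inhibitor: compound 1 (`C=C(Br)C(=O)Nc1cccc(/C=C/C(=O)Nc2ccc(F)cc2)c1`) gives 16800 nM, compound 2 (`C=C(Br)C(=O)Nc1cccc(/C=C/C(=O)Nc2cccc(F)c2)c1`) gives 1200 nM and compound 3 (`C=C(Br)C(=O)Nc1cccc(/C=C/C(=O)Nc2ccc(C)cc2)c1`) gives 1500 nM. Compound 3 therefore stands level with compound 2, as a 1.3-fold higher number from compound 2 to compound 3 (0.10 log units; within the scatter) shows, and well apart from compound 1.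

The next compound, compound 4 (`C=C(Br)C(=O)Nc1cccc(/C=C/C(=O)Nc2ccc(OC)cc2)c1`), carries methoxy in place of methyl on an aromatic carbon, para to a large group: methoxy in place of methyl on an aromatic carbon. Within the data shown here, no measured step makes this exact change. Among the measured compounds shown here, only one measured step alters the group at that place, an 11-fold lower number from compound 1 to compound 3 (1.05 log units; beyond the scatter), and it was large. Another large step, a 14-fold lower number from compound 1 to compound 2 (1.15 log units; beyond the scatter), shows that a single change among these compounds can move the number widely, so any forecast here remains loose.

Compound 1 is the only one of the three with a high number, and methoxy has not yet been tested in this set. A step beyond the scatter is therefore not expected in this assay, although a somewhat higher number seems the likelier direction. The expected step is a 1.7-fold higher number from compound 3 to compound 4 (0.22 log units; within the scatter). For compound 4 the estimated value is 2500 nM, with an expected range from 700 nM to 10000 nM.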

Compound 4, half-maximal inhibitory concentration: 790 nM
Compound 4: middle estimate off by 3.2-fold (0.50 log units), on the high side; the range from low to high includes it.
By their numbers in this assay, from the lowest: compounds 4, 2 and 3 (each within the scatter of the next); then compound 1.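

In this assay, methoxy in place of methyl on this aromatic carbon, para to a large group, stays within the scatter (a 1.9-fold lower number from compound 3 to compound 4 (0.28 log units; within the scatter)), so the 4-methoxyphenyl and 4-methylphenyl groups cannot be told apart here. Among these compounds, compound 4 also stands level with the 3-fluorophenyl compound (a 1.5-fold lower number from compound 2 to compound 4 (0.18 log units; within the scatter)), while methoxy in place of fluoro gives a large step (a 21-fold lower number from compound 1 to compound 4 (1.33 log units; beyond the scatter)), so at this place two groups now sit far from fluoro, and compound 1 remains the only compound with a high number. Compound 2 shows that this does not extend to fluoro everywhere, as with fluoro at its other ring position it stands level with compounds 3 and 4, and nothing at hand accounts for either the large steps or the level ones.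

The compounds shown leave open whether the high number belongs to fluoro alone at this place or would also appear with chloro, trifluoromethyl or a carboxylic acid there. They also leave open whether an amine or a longer chain such as ethoxy would stay level with methoxy and methyl.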